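Cyclobutyl Amide in Place of the Methoxycyclohexyl Group

A few compounds are considered here, and "the series" means these few. Any claim that something is new, unique, unknown or untested is made for them only; others in the source may bear on it.

Compound 1 `CO[C@H]1CC[C@@H](Nc2cc(NCc3cnccc3C(F)(F)F)ncc2C#N)CC1` stands at the lower of two numbers in an assay on isolated protein for inhibition of protein kinase C theta type (Homo sapiens), read by TR-FRET, with a stated time of 2 h (on this read-out lower numbers stand for stronger inhibition and higher numbers for weaker inhibition), where compound 1 gives 58 nM. Compound 2 `N#Cc1cnc(NCc2cnccc2C(F)(F)F)cc1N[C@H]1CC[C@@H](n2cncn2)CC1` gives 100 nM in this assay, and the change a 1.7-fold higher number from compound 1 to compound 2 (0.24 log units; within the scatter) shows that swapping the group on that saturated ring carbon barely moved the result. Compound 3 `CC1(C)[C@@H](Nc2cc(NCc3cnccc3C(F)(F)F)ncc2C#N)C[C@@H]1C(N)=O` differs from compound 1 by 3-carbamoyl-2,2-dimethylcyclobutyl in place of 4-methoxycyclohexyl on a nitrogen on an aromatic ring. Within the data shown here, no measured step exchanges the ring itself, so the only guide is the tolerance seen in a 1.7-fold higher number from compound 1 to compound 2 (0.24 log units; within the scatter). Compound 3 is therefore expected to give 120 nM in this assay, within 40 nM to 400 nM, an estimated 2.1-fold higher number from compound 1 to compound 3 (0.32 log units; beyond the scatter).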

Compound 3, half-maximal inhibitory concentration: 1100 nM
Compound 3: the middle estimate sits 9.2-fold (0.96 log units) below what was measured; the measured number lies above the stated range.
By their numbers in this assay, from the lowest: compounds 1 and 2 (each within the scatter of the next); then compound 3.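

At this nitrogen on an aromatic ring the substituent is not freely exchangeable: 3-carbamoyl-2,2-dimethylcyclobutyl in place of 4-methoxycyclohexyl gives a 19-fold higher number from compound 1 to compound 3 (1.28 log units; beyond the scatter) in this assay and is a large step, whereas a 1.7-fold higher number from compound 1 to compound 2 (0.24 log units; within the scatter) stayed within the scatter. Nothing measured here bears on the reason for this rise.

Going by these compounds, the step changes ring size, the dimethyl substitution and the carbamoyl group together, so the part responsible remains open. A 4-carbamoylcyclohexyl group or an unsubstituted cyclobutyl group on the same nitrogen would begin to separate these changes.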